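Oxime series: a second methyl on the aryl ring

The source may report more compounds than this note shows. Statements on the series, on what has been measured and on what is new or still open speak of the compounds shown alone.

The series shares one core carrying an aryl group: compound 1 `O/N=C(/CCN1CCN(c2ccccn2)CC1)c1ccccc1` bears phenyl, compound 2 `Cc1cccc(/C(CCN2CCN(c3ccccn3)CC2)=N/O)c1` bears 3-methylphenyl and compound 3 `O/N=C(/CCN1CCN(c2ccccn2)CC1)c1cc(F)cc(F)c1` bears 3,5-difluorophenyl. In a functional assay on HEK293 cells with D(4) dopamine receptor (Homo sapiens) as the target, read by FLIPR (a lower number here means a smaller maximal response, a higher number a larger maximal response), compound 1 gives 74%, compound 2 gives 74% and compound 3 gives 70%. Compound 2 stands level with compound 1 at the digits shown, the two together the highest of the three numbers; its nearest is compound 1, its furthest compound 3, and both gaps lie within the scatter. Among the measured compounds shown here, the one step recorded between measured compounds, a number 4 percentage points lower from compound 1 to compound 3 (within the scatter), also lies within the scatter.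

Compound 4 `Cc1cc(C)cc(/C(CCN2CCN(c3ccccn3)CC2)=N/O)c1` has not yet been measured. The change from compound 2 is methyl in place of hydrogen on an aromatic carbon. For the measured compounds named here, only the step from compound 1 to compound 3 bears on this: a change on the same aromatic ring left the maximal response in this assay unchanged beyond the scatter, and compound 1 set against compound 2 shows the same picture for a single methyl. For compound 4 no change beyond the scatter is therefore expected, a number 2 percentage points lower from compound 2 to compound 4 (within the scatter). The estimate for compound 4 in this assay is 72%, with a range from 60% to 84%.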

Compound 4, largest response reached (reported as efficacy), in percent of the reference or control that the assay uses: 55%
The estimate for compound 4 lay 17 percentage points above the measured number; measured number below the stated range.
By their numbers in this assay, from the lowest: compound 4; then compounds 3, 1 and 2 (each within the scatter of the next).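

In this assay, the second methyl does not repeat the first: compound 1 at 74% and compound 2 at 74% stand level, yet placing methyl on the aromatic carbon meta to the existing methyl group gives a number 19 percentage points lower from compound 2 to compound 4 (beyond the scatter). Two substituents on the ring do not by themselves bring such a loss, as 3,5-difluorophenyl in place of phenyl gives only a number 4 percentage points lower from compound 1 to compound 3 (within the scatter), so compound 3 goes against any reading based on the substitution pattern alone, and among these compounds the lower maximal response is seen only with 3,5-dimethylphenyl. No measurement available here accounts for this drop.

The compounds shown leave open whether 3,5-dichlorophenyl, 3,5-dimethoxyphenyl or 3,5-diethylphenyl would stay with compound 3 or fall with compound 4, and so whether the loss is particular to two methyl groups. They also leave open whether a single ethyl or methoxy group in place of the methyl of compound 2 would already lower the maximal response in this assay.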